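Three Limits and a Fourth Compound Awaiting Measurement

The source may hold more compounds than are shown below. What is called first, only, known or untested is meant among the compounds shown, and "the series" means these compounds.

Compound 1 `CCNC(=O)N1CCN(C(=S)SCc2cn(Cc3ccc(Cl)cc3)nn2)CC1` was tested in a functional assay on MCF7 cells (Homo sapiens) for cytotoxicity, read by MTT assay, with a stated time of 72 h; a lower number here means a stronger inhibitor, a higher number a weaker inhibitor. In this assay compound 1 reached only the limit > 128000 nM, a bound of the test rather than a number. Compound 2 `CC(C)NC(=O)N1CCN(C(=S)SCc2cn(Cc3ccc(Cl)cc3)nn2)CC1` differs from compound 1 by methyl in place of hydrogen on a saturated chain carbon bound to an amide-type nitrogen and a saturated chain carbon. In this assay compound 2 likewise gave the limit > 128000 nM. The step that the two limits leave unreadable from compound 1 to compound 2 therefore has no readable size. Compound 3 `CCNC(=O)N1CCN(C(=S)SCc2cn(Cc3ccc(C)cc3)nn2)CC1` carries a different core, set apart from the core of compound 1 by methyl in place of chloro on an aromatic carbon. In this assay compound 3 also stopped at the limit > 128000 nM. The step that the two limits leave unreadable from compound 1 to compound 3 is equally unreadable, as every value sits at the limit of > 128000 nM in this assay, at which 3 of the 3 values shown sit.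

Compound 4 `Cc1ccc(Cn2cc(CSC(=S)N3CCN(C(=O)NC(C)C)CC3)nn2)cc1` has not been measured. It differs from compound 3 by methyl in place of hydrogen on a saturated chain carbon bound to an amide-type nitrogen and a saturated chain carbon, the same change that separates compound 1 from compound 2, made at the same place; this change occurs twice among the compounds shown, and its first occurrence, between two limits, yielded no measurable step. Because all three measured values rest at the limit of > 128000 nM in this assay, at which 3 of the 3 values shown sit, the step is expected to be a step that the limit leaves unreadable from compound 3 to compound 4. Compound 4 is expected at 200000 nM, most likely between 100000 nM and 600000 nM, and most probably again only as a limit.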

Compound 4, half-maximal inhibitory concentration: 4630 nM
Beside the measured number, compound 4's estimate is 43-fold (1.64 log units) above it, and the stated range ends above it.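

In this assay, ethyl to isopropyl on the core of compound 3 gives an at least 27-fold lower number from compound 3 to compound 4 (1.44 log units; beyond the scatter), while methyl in place of chloro with the isopropyl group kept gives an at least 27-fold lower number from compound 2 to compound 4 (1.44 log units; beyond the scatter). On the core of compound 1, the same ethyl to isopropyl change yields compound 2 at > 128000 nM, which is a limit of the test and not a number, so the clear drop seen on the methyl-bearing core does not visibly carry over to the chloro-bearing core. The true size of the drop on either core stays unknown, and the steps among compounds 1, 2 and 3 cannot be read: the limit of > 128000 nM in this assay, at which 3 of the 4 values shown sit.

With a single measured number, the compounds shown leave open whether the pairing of methyl and isopropyl is special or whether other groups would also give a measurable value. A tert-butyl group in place of the isopropyl, or a methoxy group in place of the methyl on the aromatic carbon, would begin to test this.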